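Chlorotriazine series: propylamino in place of tert-butylamino

The source may hold more compounds than are shown below. What is called first, only, known or untested is meant among the compounds shown, and "the series" means these compounds.

Measured compounds:
- compound 1, `C[C@H](Nc1nc(Cl)nc(NC(C)(C)C)n1)c1ccccc1`, in an ADME assay on the whole organism for inhibition, with Echinochloa crus-galli var. formosensis as the target, with a stated time of 4 days (on this read-out lower numbers stand for stronger inhibition and higher numbers for weaker inhibition), compound 1 gives 7410 nM
- compound 2, `CCNc1nc(Cl)nc(NC(C)c2ccccc2)n1`, in this assay compound 2 gives 9770 nM
- compound 3, `CCCN(C)c1nc(Cl)nc(N[C@H](C)c2ccccc2)n1`, in this assay compound 3 gives 9770 nM

All three numbers in this assay lie within the usual scatter of one another. Among the compounds with values here, compound 1 stands among them with no clear separation: its nearest, compound 2, and its furthest, compound 3, are both within the scatter of it, so no compound of the three is set apart as stronger or weaker. No pair of these compounds differs in only one place, so no single step between measured compounds can be read off.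

Compound 4, `CCCNc1nc(Cl)nc(N[C@@H](C)c2ccccc2)n1`, is not yet measured in this assay. It differs from compound 1 in one place: propyl in place of tert-butyl on a nitrogen on an aromatic ring. The change leaves the shared core and the other amino substituent untouched. Within the data shown here, nothing among the measured compounds speaks for a shift beyond the scatter on this change, as the three different amino groups already seen give numbers within the scatter of each other.

The step of a 1.2-fold higher number from compound 1 to compound 4 (0.08 log units; within the scatter) is expected to be none beyond the scatter. For compound 4 the expected value in this assay is 9000 nM, with a range from 4000 nM to 20000 nM.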

Compound 4, half-maximal inhibitory concentration: 15100 nM
For compound 4 the middle estimate is 1.7-fold (0.22 log units) below the measured one; the measured number falls inside the stated range.
By their numbers in this assay, from the lowest: compounds 1, 2, 3 and 4 (each within the scatter of the next, the first and the last beyond it).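

In this assay, the amino substituent on the shared core now has its first step that can be read at a single place: propyl in place of tert-butyl on a nitrogen on an aromatic ring gives a 2.0-fold higher number from compound 1 to compound 4 (0.31 log units; beyond the scatter), toward weaker inhibition. Within the data shown here, the step is modest but lies beyond the usual scatter, so this position is not indifferent to the change, which the earlier compounds could not show because no pair among them differed in only one place. No supporting data bear on what lies behind this step.

From the compounds shown here alone, it remains open whether the step follows from losing tert-butyl or from propyl itself, and a cyclobutyl group, an isopropyl group or a longer chain such as pentyl on the same nitrogen would help separate the two readings. Going by these compounds, it is also open whether the same exchange carries over when the other amino substituent on the shared core is replaced, for example by a benzylamine, since a single pair gives this change in one setting only.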